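A few compounds are considered here, and "the series" means these few. Any claim that something is new, unique, unknown or untested is made for them only; others in the source may bear on it.

Measured so far:
Compound 1, `CC(CCNC(=O)c1c(Cl)cncc1Cl)N1CCC(C(Oc2cccc(C#N)n2)c2ccc(C(F)(F)F)cc2)CC1`: 15700 nM
Compound 2, `Cc1cccc(OC(c2ccc(Br)cc2)C2CCN(C(C)CCNC(=O)c3c(Cl)cncc3Cl)CC2)n1`: 6500 nM
Compound 3, `CCO/N=C(/c1ccc(Br)cc1)C1CCN(CCCNC(=O)c2c(C)cc[n+]([O-])c2C)CC1`: 7500 nM

These numbers come from an ADME assay on PBMC cells (Homo sapiens) for cytotoxicity; a higher number here means that more compound is tolerated, a lower number that less compound is tolerated. Among the three, compound 1 has the highest number, meaning the most compound is tolerated; both compound 2 and compound 3 lie beyond the usual scatter beneath it. Compound 4, `COC(=O)c1cccc(OC(c2ccc(C(F)(F)F)cc2)C2CCN(C(C)CCNC(=O)c3c(Cl)cncc3Cl)CC2)n1`, has not yet been measured. It differs from compound 1 in one place: methoxycarbonyl in place of cyano on an aromatic carbon. Going by the values given here, no measured pair shows this same exchange, so there is nothing among the measured compounds to lean on for its effect. The step expected from this change, a 1.3-fold lower number from compound 1 to compound 4 (0.12 log units; within the scatter), is therefore taken as none beyond the scatter. Compound 4 is expected to give 12000 nM, with a range from 5000 nM to 30000 nM.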

Compound 4, half-maximal cytotoxic concentration: 14600 nM
For compound 4 the middle estimate is 1.2-fold (0.09 log units) below the measured one, and the stated range covers the measured number.
By their numbers in this assay, from the lowest: compounds 2, 3, 4 and 1 (each within the scatter of the next, the first and the last beyond it).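

In this assay, methoxycarbonyl in place of cyano on the aromatic carbon next to the ring nitrogen gives a 1.1-fold lower number from compound 1 to compound 4 (0.03 log units; within the scatter). So, for this pair, the larger methoxycarbonyl group at this position gives a number that cannot be told apart from that of the nitrile. No measurement at hand offers an explanation for this result. Open, from the compounds shown here alone, is how a carboxylic acid or an amine at this position would read. Also open, going by these compounds, is whether the same exchange gives a similar step when bromine replaces trifluoromethyl elsewhere in the molecule.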